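Replacing the Hydroxyphenyl Ester Arm with a Nitro Group

This account rests on a few compounds, and the source may have more. Where it says the series, first, only, none or still open, it means among the compounds named here.

Three compounds have been measured in an ADME assay on a cell-free system (plasma, Homo sapiens) for metabolic stability, with Plasma (Rattus norvegicus) as the target, read by HPLC, at pH 7.4; a higher number here means that the compound lasts longer, a lower number that the compound disappears faster:

Compound 1 `CC(=O)Oc1ccccc1C(=O)O[C@H]1CO[C@H]2[C@@H]1OC[C@H]2OC(=O)c1cccc(O)c1` gives 0.015 h
Compound 2 `CCC(=O)O[C@@H]1CO[C@H]2[C@@H]1OC[C@@H]2OC(=O)c1ccccc1OC(C)=O` gives 0.011 h
Compound 3 `CC(=O)Oc1ccccc1C(=O)O[C@H]1CO[C@H]2[C@@H]1OC[C@H]2OC(=O)c1ccc(C)cc1` gives 0.0362 h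

Compound 1 stands second highest of the three numbers. Its nearest neighbour is compound 2, reached by a 1.4-fold lower number from compound 1 to compound 2 (0.13 log units; within the scatter), a step within the scatter. The furthest is compound 3, reached by a 2.4-fold higher number from compound 1 to compound 3 (0.38 log units; beyond the scatter), a modest step beyond the scatter. Compound 2 and compound 3 are joined by a 3.3-fold higher number from compound 2 to compound 3 (0.52 log units; beyond the scatter).

Compound 4 `CC(=O)Oc1ccccc1C(=O)O[C@H]1CO[C@H]2[C@@H]1OC[C@H]2O[N+](=O)[O-]` has not yet been measured in this assay. It differs from compound 1 in this way: nitro in place of (3-hydroxyphenyl)carbonyl on an oxygen on a saturated carbon.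

For the measured compounds named here, no measured step swaps in a nitro group, so no step bears on the change directly. The two steps that start from compound 1 alter the group on the same carbonyl carbon and move the number by a 1.4-fold lower number from compound 1 to compound 2 (0.13 log units; within the scatter) and a 2.4-fold higher number from compound 1 to compound 3 (0.38 log units; beyond the scatter), that is, little to modestly. By that pattern of small movements, compound 4 is expected to land near compound 1, with at most a modest rise, a step of a 1.5-fold higher number from compound 1 to compound 4 (0.17 log units; within the scatter). The estimate for compound 4 in this assay is 0.022 h, with a range from 0.008 h to 0.06 h.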

Compound 4, half-life: 0.00314 h
For compound 4 the middle estimate is 7.0-fold (0.85 log units) above the measured one, outside the stated range (below it).
By their numbers in this assay, from the lowest: compound 4; then compounds 2 and 1 (each within the scatter of the next); then compound 3.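

In this assay, for the compounds shown here, the group on this oxygen on a saturated carbon can pull the number down further than swaps among carbonyl groups did: nitro in place of (3-hydroxyphenyl)carbonyl brings a 4.8-fold lower number from compound 1 to compound 4 (0.68 log units; beyond the scatter) and is the first change here that removes the carbonyl from this oxygen. The fall is not limited to one partner, since nitro in place of (4-methylphenyl)carbonyl brings a 12-fold lower number from compound 3 to compound 4 (1.06 log units; beyond the scatter) and nitro in place of propanoyl, a chain with no aromatic ring, brings a 3.5-fold lower number from compound 2 to compound 4 (0.54 log units; beyond the scatter) and so leaves compound 4 with the lowest number of the four. Nothing available here explains why the number falls with nitro on this oxygen.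

Nitro is the only group shown on this oxygen without a carbonyl, so the result cannot say whether the fall belongs to nitro itself or would also follow from a plain hydroxyl or a methyl group in its place. Going by these compounds, a carbonyl partner carrying an amine or a carboxylic acid also remains open, as does a longer chain than propanoyl.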